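The source may report more compounds than this note shows. Statements on the series, on what has been measured and on what is new or still open speak of the compounds shown alone.

Compound 1 `CSc1nc(Cl)c(C(=O)c2ccccc2)s1`: > 100000 nM
Compound 2 `CSc1nc(Br)c(C(=O)c2ccccc2)s1`: > 100000 nM

In a functional assay on Hs 683 cells (Homo sapiens) for cytotoxicity, read by MTT assay, with a stated time of 72 h (a lower number here means a stronger inhibitor, a higher number a weaker inhibitor), compound 1 gives > 100000 nM, which is a limit and not a number. Compound 2 gives > 100000 nM, which is also a limit. The series therefore stands at the limit of > 100000 nM in this assay, at which 2 of the 2 values shown sit, and compound 1 has no readable position within it.

Compound 3 `O=C(c1ccccc1)c1sc(N2CCCCC2)nc1Cl` carries piperidin-1-yl in place of methylsulfanyl on an aromatic carbon. For the measured compounds named here, the only measured step is a step that the two limits leave unreadable from compound 1 to compound 2, bromo in place of chloro on an aromatic carbon. It has no readable size and leaves the methylsulfanyl group untouched, so it gives no guide to this change. In this assay only a modest move towards stronger inhibition is expected, and a further limit remains likely. The estimated step is an at least 1.4-fold lower number from compound 1 to compound 3 (0.15 log units; that floor lies within the scatter). Compound 3 is expected at 70000 nM, with an estimated range of 20000 nM to 200000 nM.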

Compound 3, half-maximal inhibitory concentration: 36000 nM
Compound 3: the middle estimate sits 1.9-fold (0.29 log units) above what was measured; the range from low to high includes it.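

In this assay, for the compounds shown here, the carbon bearing methylsulfanyl proves to be a place where a change can be read: piperidin-1-yl there gives an at least 2.7-fold lower number from compound 1 to compound 3 (0.44 log units; beyond the scatter), and compound 3, at 36000 nM, carries the first value that is a number. From the compounds shown here alone, this step is only a floor, as compound 1 holds a limit and not a number, so the full size of the change stays unknown. The swap of chloro for bromo could not be read, and the series now has a single value off the limit: the limit of > 100000 nM in this assay, at which 2 of the 3 values shown sit.

Going by these compounds, whether the ring of piperidin-1-yl matters, or only the nitrogen on the aromatic carbon, stays open; a morpholin-4-yl group or an open-chain diethylamino group would bear on this. Also open, on these data alone, is whether bromo in place of chloro can be read once piperidin-1-yl is present.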